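Cytotoxicity notes: from compound 3 to compound 4

The source may hold more compounds than are shown below. What is called first, only, known or untested is meant among the compounds shown, and "the series" means these compounds.

- compound 1 `O=C1C(=Cc2ccc(O)cc2)C(=O)N(c2ccc(Cl)cc2)N1c1ccc(Cl)cc1` gives 19500 nM
- compound 2 `O=C1C(=Cc2ccc(Br)cc2)C(=O)N(c2ccc(Cl)cc2)N1c1ccc(Cl)cc1` gives 16900 nM
- compound 3 `COc1ccccc1C=C1C(=O)N(c2ccc(Cl)cc2)N(c2ccc(Cl)cc2)C1=O` gives 28600 nM

In a functional assay on MGC-803 cells (Homo sapiens) for cytotoxicity, read by MTT assay, with a stated time of 72 h (a higher number here means a weaker inhibitor, a lower number a stronger inhibitor), compound 3 gives 28600 nM and sits close to both others, with a 1.5-fold higher number from compound 1 to compound 3 (0.17 log units; within the scatter) and a 1.7-fold higher number from compound 2 to compound 3 (0.23 log units; within the scatter) both within the scatter. Compound 4 `O=C1C(=Cc2c[nH]c3ccccc23)C(=O)N(c2ccc(Cl)cc2)N1c1ccc(Cl)cc1` carries the change 1H-indol-3-yl in place of 2-methoxyphenyl on a double-bonded chain carbon bound to a double-bonded ring carbon on the shared core. The two steps just given act at that same place, and a 1.2-fold lower number from compound 1 to compound 2 (0.06 log units; within the scatter) on an aromatic carbon also stays within the scatter. Among the compounds with values here, none of them brings in 1H-indol-3-yl, so the data hold no direct precedent. With a 1.7-fold higher number from compound 2 to compound 3 (0.23 log units; within the scatter) as a guide, no step beyond the scatter is expected in this assay here. The estimated step is a 1.6-fold lower number from compound 3 to compound 4 (0.20 log units; within the scatter) at the middle of the range. Compound 4 is estimated at 18000 nM within an expected range of 6000 nM to 40000 nM for now.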

Compound 4, half-maximal inhibitory concentration: 21800 nM
The estimate for compound 4 lay 1.2-fold (0.08 log units) below the measured number; the measured number falls inside the stated range.
By their numbers in this assay, from the lowest: compounds 2, 1, 4 and 3 (each within the scatter of the next).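

Within the data shown here, at this place on the shared core, 1H-indol-3-yl, the only group here with a five-membered aromatic ring and a ring nitrogen, stays within the scatter of all three earlier compounds in this assay (a 1.3-fold lower number from compound 3 to compound 4 (0.12 log units; within the scatter); a 1.3-fold higher number from compound 2 to compound 4 (0.11 log units; within the scatter); a 1.1-fold higher number from compound 1 to compound 4 (0.05 log units; within the scatter)). The place on a double-bonded chain carbon has thus taken four different aromatic groups, one of them with two rings, without a step beyond the scatter. No measurement at hand accounts for this flat picture.

On these data alone, whether an amine or a carboxylic acid on a longer chain would move the number beyond the scatter remains open. Changes elsewhere on the shared core also remain open.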